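A few compounds are considered here, and "the series" means these few. Any claim that something is new, unique, unknown or untested is made for them only; others in the source may bear on it.

In a functional assay on A549 cells (Homo sapiens) for inhibition, read by XTT assay, with a stated time of 48 h (on this read-out lower numbers stand for stronger inhibition and higher numbers for weaker inhibition), compound 1 `C=C(C(=O)c1ccc(OC)cc1)C(OC(C)=O)c1ccc(Cl)cc1Cl` gives 17600 nM and compound 2 `C=C(C(=O)c1ccc(OC)cc1)C(OC(C)=O)C(CC)CC` gives 32900 nM, a pair separated by a 1.9-fold higher number from compound 1 to compound 2 (0.27 log units; within the scatter). Compound 3 `C=C(C(=O)c1ccc(OC)cc1)C(OC(C)=O)C1CCCCC1` reaches only a limit in this assay, > 100000 nM. Compound 4 `C=C(C(=O)c1ccc(OC)cc1)C(OC(=O)c1ccccc1)c1ccc(Cl)cc1Cl` departs from compound 1 by phenyl in place of methyl on a carbonyl carbon. Within the data shown here, no measured step alters that carbonyl carbon: the changes an at least 5.6-fold higher number from compound 1 to compound 3 (0.75 log units; beyond the scatter) and an at least 3.0-fold higher number from compound 2 to compound 3 (0.48 log units; beyond the scatter) concern the group on the saturated chain carbon instead, so they describe the spread of this assay rather than the present change. The account therefore expects no step beyond the scatter, an estimated 1.0-fold lower number from compound 1 to compound 4 (0.02 log units; within the scatter). Compound 4 is estimated at 17000 nM, within a range from 6000 nM to 50000 nM.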

Compound 4, half-maximal inhibitory concentration: 79200 nM
Compound 4: middle estimate off by 4.7-fold (0.67 log units), on the low side, and the stated range ends below it.
By their numbers in this assay, from the lowest: compounds 1 and 2 (each within the scatter of the next); then compound 4. At a limit, above all of these: compound 3.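

In this assay, the change from acetoxy to benzoyloxy, phenyl in place of methyl on a carbonyl carbon, gives a 4.5-fold higher number from compound 1 to compound 4 (0.65 log units; beyond the scatter). Among these compounds, this shows that the carbonyl carbon also affects the read-out, which the earlier steps, all made on the saturated chain carbon, could not show. Nothing measured here accounts for this change. The compounds shown leave open how a longer chain or an amine on this carbonyl carbon would read, and whether benzoyloxy has a similar effect alongside pentan-3-yl or cyclohexyl.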